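A few compounds are considered here, and "the series" means these few. Any claim that something is new, unique, unknown or untested is made for them only; others in the source may bear on it.

Compound 1 (`COc1cc(/C=C(\C#N)C(=O)N/N=C(\C)c2c(O)c3ccc(O)cc3oc2=O)ccc1O`) gives 14400 nM
Compound 2 (`COc1ccc(/C=C(\C#N)C(=O)N/N=C(\C)c2c(O)c3ccc(O)cc3oc2=O)cc1OC`) gives 21500 nM

Both numbers come from a functional assay on SK-N-SH cells (Homo sapiens) for cytotoxicity, read by MTT assay, with a stated time of 24 h (a lower number here means a stronger inhibitor, a higher number a weaker inhibitor), and they cannot be told apart: the measured step is a 1.5-fold higher number from compound 1 to compound 2 (0.17 log units; within the scatter) and it places compound 2 level with compound 1. Compound 3 (`COc1ccc(/C=C(\C#N)C(=O)N/N=C(\C)c2c(O)c3ccc(O)cc3oc2=O)cc1`) is reached from compound 2 by hydrogen in place of methoxy on an aromatic carbon, which turns 3,4-dimethoxyphenyl into 4-methoxyphenyl. For the measured compounds named here, no measured step removes a methoxy. The nearest evidence is that same step, a 1.5-fold higher number from compound 1 to compound 2 (0.17 log units; within the scatter), which concerns a different oxygen on the ring and stayed small. A change beyond the scatter is therefore not expected in this assay, and no direction can be favoured. The expected move is a 1.1-fold lower number from compound 2 to compound 3 (0.03 log units; within the scatter) and it carries little weight. Compound 3 is estimated at 20000 nM with an expected range of 9000 nM to 45000 nM in this measurement.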

Compound 3, half-maximal inhibitory concentration: 9460 nM
The estimate for compound 3 lay 2.1-fold (0.33 log units) above the measured number; the measured number falls inside the stated range.
By their numbers in this assay, from the lowest: compounds 3, 1 and 2 (each within the scatter of the next, the first and the last beyond it).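

In this assay, the step of a 2.3-fold lower number from compound 2 to compound 3 (0.36 log units; beyond the scatter) is the first one shown that lies beyond the scatter, though it is modest. It indicates that the methoxy on this aromatic carbon, ortho to a methoxy group and meta to a large group, has a measurable bearing on the number, whereas the earlier change of hydrogen to methyl on the ring oxygen did not. The other new step, a 1.5-fold lower number from compound 1 to compound 3 (0.18 log units; within the scatter), leaves 4-methoxyphenyl and 4-hydroxy-3-methoxyphenyl indistinguishable here, and nothing measured accounts for the difference between compound 2 and compound 3.

On these data alone, what an amine or a chlorine on this carbon would do remains open. As far as these compounds go, the role of the remaining methoxy is also open, and a longer chain such as ethoxy in its place would test it.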